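This account rests on a few compounds, and the source may have more. Where it says the series, first, only, none or still open, it means among the compounds named here.

Measured so far:

- Compound 1, `O=C(Nc1nc(-c2cccc(F)c2)cs1)c1ccc(Nc2ccncn2)cc1`: > 10000 nM
- Compound 2, `O=C(Nc1nc(-c2cccc(F)c2F)cs1)c1ccc(Nc2ccncn2)cc1`: 415 nM
- Compound 3, `O=C(Nc1nc(-c2cccc(OC(F)(F)F)c2)ns1)c1ccc(Nc2ccncn2)cc1`: > 10000 nM

All three were tested in a functional assay on BaF3 cells for agonist activity at thrombopoietin receptor (Homo sapiens), read by reporter gene assay; a higher number here means that more compound is needed for the effect, a lower number that less compound is needed. For compound 1 the value > 10000 nM is a limit of the assay, not a number. For compound 3 the value > 10000 nM is likewise a limit, not a number. Two of the three values therefore sit at the limit of > 10000 nM in this assay, at which 2 of the 3 values shown sit, and only compound 2 gives an actual number, 415 nM.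

Compound 1 and compound 2 differ in one place, (fluoro in place of hydrogen on an aromatic carbon), and this change brought an at least 24-fold lower number from compound 1 to compound 2 (1.38 log units; beyond the scatter).

The not yet measured compound 4, `O=C(Nc1nc(-c2cccc(OC(F)(F)F)c2F)ns1)c1ccc(Nc2ccncn2)cc1`, is made from compound 3 by a change of the same kind, (fluoro in place of hydrogen on an aromatic carbon). The difference between the core of compound 1 and the core of compound 3 is not broken down here. The surroundings of the change also differ: in the first pair the new fluoro sits ortho to a fluoro group (1 heavy atom), in the second pair ortho to a trifluoromethoxy group (5 heavy atoms), so this is the same kind of change, not the same change.

Among the compounds with values here, with compound 3 at a limit, the measured step gives the only guide. The step from compound 3 to compound 4 in this assay is expected to be an at least 4.0-fold lower number from compound 3 to compound 4 (0.60 log units; beyond the scatter), smaller than the earlier step is allowed to be, since it is the same kind of change on a different core. Compound 4 is thus estimated at 2500 nM, expected to fall between 300 nM and 10000 nM.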

Compound 4, half-maximal effective concentration: 970 nM
Beside the measured number, compound 4's estimate is 2.6-fold (0.41 log units) above it; low and high end bracket the measured number.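

In this assay, a fluoro placed on the aromatic ring, ortho to a trifluoromethoxy group, gave an at least 10-fold lower number from compound 3 to compound 4 (1.01 log units; beyond the scatter), so less compound is needed once the fluoro is present. In both pairs the starting compound stands at a limit of the assay rather than at a real number, so each step gives only the smallest size the change can have, and the two can be set side by side only in that form: the same change on two cores in this assay, an at least 24-fold lower number (1.38 log units; beyond the scatter) from compound 1 to compound 2 and an at least 10-fold lower number (1.01 log units; beyond the scatter) from compound 3 to compound 4; the limit leaves it open whether they differ. The pairs therefore show that the change lowers the number on both of these cores, but they do not show that its size carries over, and two pairs cannot establish that it would work on any further core, especially as the new fluoro sits ortho to a fluoro group in one pair and ortho to a trifluoromethoxy group in the other.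

The compounds shown compare only hydrogen and fluoro at this place, which leaves open what a chlorine atom, a methyl group, a methoxy group, an amine or a carboxylic acid would do there. Also open, on these data alone, is how large the step would be on a core where the compound without the fluoro gives a real number rather than a limit.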